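Enlarging the sulfonyl substituent on compound 3

The source may report more compounds than this note shows. Statements on the series, on what has been measured and on what is new or still open speak of the compounds shown alone.

Of the compounds shown here, three have been measured in an ADME assay on microsomes from liver (Mus musculus) for metabolic stability, read by LC-MS, with a stated time of 60 min, tested at 10 uM; on this read-out higher numbers stand for a longer-lived compound and lower numbers for a shorter-lived compound. Compound 1 (`CC(C)c1noc(C2CCN(C(=O)[C@@H]3CCCN(S(=O)(=O)c4ccc(S(=O)(=O)C(C)C)cc4)C3)CC2)n1`) gives 0.543 h, and compound 2 (`CCN(CC)C(=O)c1ccc(S(=O)(=O)N2CCC[C@@H](C(=O)N3CCN(c4nc(C(C)C)no4)CC3)C2)cc1`) gives 0.175 h. Compound 3 (`CC(C)c1noc(N2CCN(C(=O)[C@@H]3CCCN(S(=O)(=O)c4ccc(S(=O)(=O)C(C)C)cc4)C3)CC2)n1`) gives > 1 h, which is a limit of the assay and not a number.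

Compound 4 (`CCC(CC)S(=O)(=O)c1ccc(S(=O)(=O)N2CCC[C@@H](C(=O)N3CCN(c4nc(C(C)C)no4)CC3)C2)cc1`) has not yet been measured. It differs from compound 3 in one place: pentan-3-yl in place of isopropyl on a sulfonyl sulfur. In plain words, pentan-3-yl stands in place of isopropyl on a sulfonyl sulfur.

Among the compounds with values here, one measured step bears on this change, though only indirectly: an at least 5.7-fold higher number from compound 2 to compound 3 (0.75 log units; beyond the scatter). That step lies beyond the scatter, but it replaced a group on an aromatic carbon and left the isopropyl untouched. Within the data shown here, no measured step alters the group on the sulfonyl sulfur, so the size of this change remains uncertain, and compound 4 could still reach the limit.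

The estimated step is an at least 1.2-fold lower number from compound 3 to compound 4 (0.09 log units; that floor lies within the scatter), a small and downward move in this assay. For compound 4 the expected half-life is 0.8 h, with an estimated range from 0.35 h to 1.5 h.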

Compound 4, half-life: 0.13 h
The estimate for compound 4 lay 6.2-fold (0.79 log units) above the measured number; the whole stated range lies above it.
By their numbers in this assay, from the lowest: compounds 4 and 2 (each within the scatter of the next); then compound 1. At a limit, above all of these: compound 3.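

In this assay, within the data shown here, the group on the sulfonyl sulfur turns out to matter: pentan-3-yl in place of isopropyl gives an at least 7.6-fold lower number from compound 3 to compound 4 (0.88 log units; beyond the scatter), and no earlier step had touched this position. The advantage that isopropylsulfonyl showed over diethylcarbamoyl does not survive with (pentan-3-yl)sulfonyl, which gives a 1.3-fold lower number from compound 2 to compound 4 (0.13 log units; within the scatter). The full size of the drop stays unknown, as compound 3 stands at a limit of the assay and not at a number: the limit of > 1 h in this assay, at which 1 of the 4 values shown sits.

Only isopropyl and pentan-3-yl stand on this sulfur here, so a single change cannot show how the half-life responds across other groups at this position. Going by these compounds, whether a methyl, a cyclopropyl or a tert-butyl would keep the half-life of compound 3 or lose it as compound 4 does remains open.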